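A few compounds are considered here, and "the series" means these few. Any claim that something is new, unique, unknown or untested is made for them only; others in the source may bear on it.

The measured compounds so far:

Compound 1, `COc1ccc(-c2csc(NC(=O)COc3ccc(C(=O)c4ccc(C)cc4)cc3C)n2)cc1`, gives in a functional assay on DLA cells (Mus musculus) for cytotoxicity, read by MTT assay, with a stated time of 48 h (a lower number here means a stronger inhibitor, a higher number a weaker inhibitor), a value of 17200 nM.
Compound 2, `COc1ccc(-c2csc(NC(=O)COc3ccc(C(=O)c4ccc(F)cc4)cc3C)n2)cc1`, gives in this assay 5400 nM.
Compound 3, `Cc1cc(C(=O)c2ccccc2F)ccc1OCC(=O)Nc1nc(-c2ccccc2)cs1`, gives in this assay 14800 nM.

Compound 2 and compound 1 share one core and differ in a single place, described as methyl in place of fluoro on an aromatic carbon. That change produced a 3.2-fold higher number from compound 2 to compound 1 (0.50 log units; beyond the scatter), so the methyl compound is the weaker inhibitor of the two. Compound 3 is built on another core; the difference between the core of compound 3 and the core of compound 2 is not broken down here. The value of compound 3 sits within the scatter of compound 1 and beyond the scatter of compound 2.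

Compound 4, `Cc1cc(C(=O)c2ccccc2C)ccc1OCC(=O)Nc1nc(-c2ccccc2)cs1`, has not yet been measured. It differs from compound 3 as methyl in place of fluoro on an aromatic carbon. Within the data shown here, this is the same kind of change as the one from compound 2 to compound 1, but not the same: in the measured pair the changed group sits para to a large group, whereas in compound 4 it sits ortho to a large group. Among the measured compounds shown here, only one measured example of this change exists, and it comes from the other core, so the expectation rests on a thin basis. Because a 3.2-fold higher number from compound 2 to compound 1 (0.50 log units; beyond the scatter) pointed toward weaker inhibition, a step of a 2.0-fold higher number from compound 3 to compound 4 (0.31 log units; beyond the scatter) in this assay is expected from compound 3 to compound 4. Compound 4 is therefore estimated at 30000 nM, most likely between 12000 nM and 80000 nM.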

Compound 4, half-maximal inhibitory concentration: 23100 nM
For compound 4 the middle estimate is 1.3-fold (0.11 log units) above the measured one; measured number inside the range.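

In this assay, replacing 2-fluorophenyl with 2-methylphenyl gave a 1.6-fold higher number from compound 3 to compound 4 (0.19 log units; within the scatter), so this step alone cannot be told apart from the ordinary variation between repeated measurements. Set beside the earlier example, the new step has the same direction, and the two sizes do not differ by more than the scatter allows: the same change on two cores in this assay, a 3.2-fold higher number (0.50 log units; beyond the scatter) from compound 2 to compound 1 and a 1.6-fold higher number (0.19 log units; within the scatter) from compound 3 to compound 4, 2.0-fold (0.31 log units) apart, within the scatter of two such steps. This is consistent with the change carrying over from one core to the other, but two pairs cannot establish a general rule or fix a size for the step, and the swap sits at a different place on the ring in each pair, so any effect of the core cannot be separated from any effect of position.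

The compounds shown leave open whether a fluoro-to-methyl swap at one fixed place on the ring would give matching steps on both cores, which would separate the role of the core from that of position. They also leave open how other groups at this place, such as an amine, a carboxylic acid or a longer chain, would compare with fluoro and methyl on either core.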